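The source may report more compounds than this note shows. Statements on the series, on what has been measured and on what is new or still open speak of the compounds shown alone.

Compound 1 `Cc1nnc(SCC(=O)N/N=c2/scc(-c3ccccc3)n2-c2ccccc2)s1` gives 197 ug/mL.
Compound 2 `Cc1ccc(-c2cs/c(=N/NC(=O)CSc3nncn3C)n2-c2ccccc2)cc1` gives 130 ug/mL.
Compound 3 `O=C(CSc1ncccn1)N/N=c1/scc(-c2ccccc2)n1-c1ccccc1` gives 107 ug/mL.

All three were tested in an ADME assay on NIH3T3 cells (Mus musculus) for cytotoxicity, read by MTT assay, with a stated time of 24 h (on this read-out higher numbers stand for weaker inhibition and lower numbers for stronger inhibition), and their numbers lie within the usual scatter of one another. Compound 1 stands at one end of this narrow spread, with compound 2 nearest and compound 3 furthest, but neither gap reaches beyond the scatter. Among the compounds with values here, the one single-point step among the measured compounds, a 1.8-fold lower number from compound 1 to compound 3 (0.27 log units; within the scatter), replaces the group on the sulfur and leaves the number essentially where it was. Compound 2 differs from compound 1 in two places at once, so its number can only be read as another value in the same band.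

Compound 4 `Cc1nnc(SCC(=O)N/N=c2/scc(-c3ccc(C#N)cc3)n2-c2ccccc2)s1` is the unmeasured compound. It differs from compound 1 by cyano in place of hydrogen on an aromatic carbon, placed on the distal ring of the shared core. Within the data shown here, no measured step touches this ring alone; the only single-point step, between compound 1 and compound 3, lies elsewhere and is itself within the scatter. Nothing in the measured compounds therefore points to a change beyond the scatter in this assay in either direction. Compound 4 is expected to give about 170 ug/mL, with a range from 85 ug/mL to 340 ug/mL. For compound 4 this estimate means an expected step of a 1.2-fold lower number from compound 1 to compound 4 (0.06 log units; within the scatter), within the scatter.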

Compound 4, half-maximal inhibitory concentration: < 3.9 ug/mL
Compound 4 gave a limit, no number; the forecaster's own chance of this, stated with the estimate: 5%; at least 43-fold (1.63 log units) between middle value and limit.
By their numbers in this assay, from the lowest: compounds 3, 2 and 1 (each within the scatter of the next). At a limit, below all of these: compound 4.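

In this assay, cyano in place of hydrogen on an aromatic carbon, para to a large group, gives an at least 50-fold lower number from compound 1 to compound 4 (1.70 log units; beyond the scatter). This is the only step shown that lies beyond the scatter, whereas the change at the sulfur, a 1.8-fold lower number from compound 1 to compound 3 (0.27 log units; within the scatter), stays within it, so the earlier compounds gave no sign that this six-membered aromatic ring of carbon only could matter so much on this read-out. Compound 4 stands at a limit and not at a number, which leaves the full size of the step unknown: the limit of < 3.9 ug/mL in this assay, at which 1 of the 4 values shown sits.

The compounds shown leave open whether this large step belongs to cyano itself or would also follow from another group at the same place, such as an amine, a carboxylic acid or a methoxy group. They also leave open whether phenyl to 4-cyanophenyl would give a step of similar size with pyrimidin-2-yl on the sulfur, as in compound 3, and whether a number for compound 4 could be reached at lower concentrations.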